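The source may hold more compounds than are shown below. What is called first, only, known or untested is meant among the compounds shown, and "the series" means these compounds.

In a functional assay, read by spectrophotometry, with a stated time of 3 min; on this read-out higher numbers stand for weaker inhibition and lower numbers for stronger inhibition:
compound 1 `O=c1cc(/C=N\c2ccc(O)cc2)c2ccc(OCc3ccccc3)cc2o1`: 64500 nM
compound 2 `O=c1cc(/C=N\Nc2ccc([N+](=O)[O-])cc2)c2ccc(OCc3ccccc3)cc2o1`: 9510 nM

Compound 2 has the lowest number of the two in this assay; its nearest neighbour is compound 1, and the step of a 6.8-fold lower number from compound 1 to compound 2 (0.83 log units; beyond the scatter) lies beyond the scatter. Compound 3 `O=c1cc(/C=N\Nc2ccc([N+](=O)[O-])cc2[N+](=O)[O-])c2ccc(OCc3ccccc3)cc2o1` has not yet been measured. It differs from compound 2 by nitro in place of hydrogen on an aromatic carbon, on an aromatic carbon of a six-membered aromatic ring of carbon only, ortho to a large group and meta to a nitro group. Within the data shown here, the single measured step altered a different part of the molecule, so no step bears directly on this change. Only a small step is expected in this assay, toward stronger inhibition, or none beyond the scatter. Compound 3 is therefore estimated at 6000 nM, within 2000 nM to 15000 nM. The expected step is a 1.6-fold lower number from compound 2 to compound 3 (0.20 log units; within the scatter).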

Compound 3, half-maximal inhibitory concentration: 6490 nM
Beside the measured number, compound 3's estimate is 1.1-fold (0.03 log units) below it; measured number inside the range.
By their numbers in this assay, from the lowest: compounds 3 and 2 (each within the scatter of the next); then compound 1.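

In this assay, nitro in place of hydrogen on the aromatic carbon ortho to a large group gives a 1.5-fold lower number from compound 2 to compound 3 (0.17 log units; within the scatter) and so leaves compound 2 and compound 3 indistinguishable. This position therefore accepts a nitro group, with its 3 heavy atoms, without a step beyond the scatter. Nothing on hand explains this result.

On these data alone, whether an amine or a methoxy group at this same place would give a step beyond the scatter remains open. A single replacement also cannot show how far this tolerance extends.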